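The compounds below may be only part of what the source reports. "The series", "measured", "known", "first", "only" and "open" are said of these compounds alone.

Three compounds have been run in an ADME assay on the whole organism (plasma, Rattus norvegicus, strain Sprague-Dawley) for protein binding, read by LC-MS, with a stated time of 24 h; on this read-out higher numbers stand for a larger free fraction and lower numbers for a smaller free fraction. Compound 1 `CCCCN(C)C(=O)OCc1c(-c2ccc(O[C@H]3CCC[C@H](C(=O)O)C3)c(C)n2)nnn1C` gives 0.063. Compound 2 `CCCCN(C)C(=O)OCc1c(C)noc1-c1ccc(O[C@H]2CCC[C@H](C(=O)O)C2)cn1` gives 0.012, and compound 3 `CN(C(=O)OCc1c(-c2ccc(O[C@H]3CCC[C@H](C(=O)O)C3)cc2)cnn1C)C1CCCC1` gives 0.009. Compound 2 thus stands second highest of the three numbers: it sits within the scatter of compound 3, while compound 1 lies beyond the scatter with the higher number. Compound 4 `Cc1noc(-c2ccc(O[C@H]3CCC[C@H](C(=O)O)C3)cn2)c1COC(=O)N(C)C1CCCC1` is not yet measured. Against compound 2 the change is cyclopentyl in place of butyl on an amide-type nitrogen. Within the data shown here, no pair of measured compounds differs in this way alone, so the step of a 1.2-fold lower number from compound 2 to compound 4 (0.08 log units; within the scatter) is expected to stay within the scatter, if anything toward a slightly smaller number. Compound 4 is accordingly expected to give 0.01 in this assay, within a range of 0.005 to 0.02.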

Compound 4, unbound fraction: 0.009
For compound 4 the middle estimate is 1.1-fold (0.05 log units) above the measured one; low and high end bracket the measured number.
By their numbers in this assay, from the lowest: compounds 3, 4 and 2 (each within the scatter of the next); then compound 1.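

In this assay, among these compounds, the series now has its first comparison in one place, a 1.3-fold lower number from compound 2 to compound 4 (0.12 log units; within the scatter), so cyclopentyl in place of butyl on this amide-type nitrogen gives no step that can be told from scatter. An open chain and a five-membered ring of carbon only are thus not separated here, though this rests on a single pair. Nothing available bears on a reason for this result.

On these data alone, whether a longer chain or a ring carrying an amine on this nitrogen would give a step beyond the scatter remains open. So does whether cyclopentyl in place of butyl reads the same on the core of compound 1.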